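Compound 3 after the best value so far

The source may hold more compounds than are shown below. What is called first, only, known or untested is meant among the compounds shown, and "the series" means these compounds.

Measured in a physicochemical assay for solubility, measured as thermodynamic solubility, at pH 1.0; on this read-out higher numbers stand for higher solubility and lower numbers for lower solubility:
Compound 1 `CS(=O)(=O)Cc1ccc(C(=O)Nc2ccc(Cl)c(-c3ccccn3)c2)c(Cl)c1`: 110 ug/mL
Compound 2 `CS(=O)(=O)Nc1ccc(C(=O)Nc2ccc(Cl)c(-c3ccccn3)c2)c(Cl)c1`: 910 ug/mL

Of the two measured compounds, compound 2 stands highest at 910 ug/mL. Compound 3 `O=C(NCc1ccccn1)c1ccc(C(=O)Nc2ccc(Cl)c(-c3ccccn3)c2)c(Cl)c1` carries ((pyridin-2-yl)methyl)carbamoyl in place of methanesulfonamido on an aromatic carbon. Within the data shown here, only one measured step bears on this change, and it also concerns the methanesulfonamido group: an 8.3-fold higher number from compound 1 to compound 2 (0.92 log units; beyond the scatter). That step replaced a different group, so it suggests a possible size but no clear direction. In this assay, the estimated step stays within the scatter: a 1.5-fold lower number from compound 2 to compound 3 (0.18 log units; within the scatter). For compound 3 the expected value is 600 ug/mL, with an estimated range of 120 ug/mL to 2500 ug/mL.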

Compound 3, solubility: 4300 ug/mL
Estimate against measurement, compound 3: 7.2-fold (0.86 log units) below; measured number outside the range, above it.
By their numbers in this assay, from the lowest: compound 1; then compound 2; then compound 3.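

In this assay, ((pyridin-2-yl)methyl)carbamoyl on the aromatic carbon meta to a chloro group gives a 4.7-fold higher number from compound 2 to compound 3 (0.67 log units; beyond the scatter) and a 39-fold higher number from compound 1 to compound 3 (1.59 log units; beyond the scatter) for the same core. This position therefore accepts a group that brings in a six-membered aromatic ring with 1 hetero atom, and among these three compounds that group gives the highest number. No measured evidence accounts for this rise. The compounds shown leave open whether the pyridin-2-yl ring itself matters, or whether a plain carbamoyl, an amine or a carboxylic acid here would give a similar number.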